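The source may hold more compounds than are shown below. What is called first, only, known or untested is meant among the compounds shown, and "the series" means these compounds.

Two compounds carrying a shared central chain, each capped at both ends with a protected amino-acid ester, have been tested in a functional assay on the whole organism (strain Wistar) for inhibition, with Rattus norvegicus as the target, read by paw edema, with stated times of 1 h and 24 h, at a dose of 10 mg/kg by the intraperitoneal route; on this read-out lower numbers stand for less inhibition and higher numbers for more inhibition at the one dose given (going by the name of the read-out). Compound 1, with the structure `CC[C@H](C)[C@H](NC(=O)OC(C)(C)C)C(=O)Oc1ccc(/C=C/C(=O)/C=C(O)/C=C/c2ccc(OC(=O)[C@@H](NC(=O)OC(C)(C)C)[C@@H](C)CC)c(OC)c2)cc1OC`, gives 41% in this assay. For the measured compounds named here, compound 2, with the structure `COc1cc(/C=C/C(=O)/C=C(O)/C=C/c2ccc(OC(=O)[C@H](C)NC(=O)OC(C)(C)C)c(OC)c2)ccc1OC(=O)[C@H](C)NC(=O)OC(C)(C)C`, gives 5% in this assay, the lowest of the two numbers measured so far; the value of compound 1 lies higher by a margin beyond the usual scatter of repeated measurements. Compound 3, with the structure `COc1cc(/C=C/C(=O)/C=C(O)/C=C/c2ccc(OC(=O)C(C)NC(=O)OC(C)(C)C)c(OC)c2)ccc1OC(=O)C(C)NC(=O)OC(C)(C)C`, has not yet been measured. It differs from compound 2 only in how the drawing fixes its shape: the two compounds have the same atoms and bonds; at least one stereo element is drawn with a configuration in one of them and without one in the other: 2 of 5 stereo elements differ; a stereocentre at a saturated chain carbon is drawn S in compound 2 and without a configuration in compound 3; a stereocentre at a saturated chain carbon is drawn S in compound 2 and without a configuration in compound 3. Since no atoms leave or enter, the expectation is that the step from compound 2 to compound 3 in this assay, estimated as a number 5 percentage points higher from compound 2 to compound 3 (within the scatter), stays within the usual scatter, with at most a small rise because the two undrawn centres may include material other than that measured for compound 2 at 5%. Compound 3 is therefore expected to give about 10% in this assay, somewhere between 0% and 30%.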

Compound 3, a percentage reported as inhibition, in the whole organism at one dose (the size of the read-out at that dose, not a potency): 29%
Beside the measured number, compound 3's estimate is 19 percentage points below it; the range from low to high includes it.
By their numbers in this assay, from the lowest: compound 2; then compound 3; then compound 1.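

For the compounds shown here, compounds 2 and 3 give the first step in this set that can be read at a single place, and it concerns the shape of the molecule rather than its atoms. In this assay, the step is a number 24 percentage points higher from compound 2 to compound 3 (beyond the scatter), so the two saturated chain carbons in the end caps cannot be treated as a detail of the drawing, even though nothing leaves or enters. The one difference on which this step can rest is a matter of how the structure is drawn, and that is all that can be said of its origin: the fact that one of compounds 2 and 3 is drawn with a defined configuration and the other without, at the place where they differ

From the compounds shown here alone, an undrawn centre does not say which forms the sample of compound 3 contains or in what proportions, so it remains open whether the higher number belongs to a form with the opposite configuration at one or both centres, or to a mixture. Going by these compounds, it is also open whether these centres would matter in the same way in an end cap carrying a free amine in place of the protected one, or a longer chain.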